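Compound 4: Trading a Cyanocyclobutyl for a Cyanocyclopropyl

This account rests on a few compounds, and the source may have more. Where it says the series, first, only, none or still open, it means among the compounds named here.

Compound 1 `N#CCCCN([C@H](CCC(F)(F)F)C(N)=O)S(=O)(=O)c1ccc(Cl)cc1`: 27.6 10^-6 cm/s
Compound 2 `N#C[C@H]1C[C@H](CN([C@H](CCC(F)(F)F)C(N)=O)S(=O)(=O)c2ccc(Cl)cc2)C1`: 24.9 10^-6 cm/s
Compound 3 `C[C@]1(C#N)C[C@@H](CN([C@H](CCC(F)(F)F)C(N)=O)S(=O)(=O)c2ccc(Cl)cc2)C1`: 25.7 10^-6 cm/s

All three compounds were measured in an ADME assay on MDCKII-LE cells (Canis lupus familiaris) for permeability (a higher number here means that the compound crosses the layer faster, a lower number that the compound crosses the layer more slowly), and their numbers lie within the scatter of one another. Compound 3, at 25.7 10^-6 cm/s, therefore stands level with the other two, and no order can be read among them.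

The next compound is compound 4 `N#CC1(CN([C@H](CCC(F)(F)F)C(N)=O)S(=O)(=O)c2ccc(Cl)cc2)CC1`, in which 1-cyanocyclopropyl takes the place of 3-cyano-3-methylcyclobutyl on a saturated chain carbon bound to a sulfonamide nitrogen: 1-cyanocyclopropyl in place of 3-cyano-3-methylcyclobutyl on a saturated chain carbon bound to a sulfonamide nitrogen.

Among the compounds with values here, three measured steps bear on this change. Putting 3-cyanocyclobutyl in place of 2-cyanoethyl gave a 1.1-fold lower number from compound 1 to compound 2 (0.04 log units; within the scatter). Putting 3-cyano-3-methylcyclobutyl in place of 2-cyanoethyl gave a 1.1-fold lower number from compound 1 to compound 3 (0.03 log units; within the scatter). Adding methyl to the ring gave a 1.0-fold higher number from compound 2 to compound 3 (0.01 log units; within the scatter). All three were small, and none left the scatter. Within the data shown here, no measured compound carries the 1-cyanocyclopropyl group, so the new ring itself remains untested in this assay.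

On these three steps, no change beyond the scatter is expected in this assay, and no direction can be favoured. The expected change is a 1.0-fold lower number from compound 3 to compound 4 (0.01 log units; within the scatter). For compound 4 the estimated value is 25 10^-6 cm/s, with an expected range from 16 10^-6 cm/s to 37 10^-6 cm/s.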

Compound 4, apparent permeability: 29.9 10^-6 cm/s
Beside the measured number, compound 4's estimate is 1.2-fold (0.08 log units) below it; the range from low to high includes it.
By their numbers in this assay, from the lowest: compounds 2, 3, 1 and 4 (each within the scatter of the next).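

In this assay, the place on a saturated chain carbon bound to a sulfonamide nitrogen now carries a three-membered ring of carbon, and all three new comparisons stay within the scatter: a 1.2-fold higher number from compound 3 to compound 4 (0.07 log units; within the scatter), a 1.2-fold higher number from compound 2 to compound 4 (0.08 log units; within the scatter), and a 1.1-fold higher number from compound 1 to compound 4 (0.03 log units; within the scatter). Within the data shown here, compound 4 thus extends to 1-cyanocyclopropyl what the earlier compounds showed only for 2-cyanoethyl and the two cyanocyclobutyl groups, and a group of 5 heavy atoms in place of the 7 in 3-cyano-3-methylcyclobutyl does not set compound 4 apart from compound 3. No supporting measurement is available for explaining these numbers.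

All four compounds keep a nitrile in the group at this place, so the compounds shown leave open whether the numbers would stay level with an amine or a carboxylic acid there instead. They also leave open how this assay would read for a longer chain ending in a nitrile or for a five-membered carbon ring bearing one.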